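Swapping a fluorobenzyl amine for a dichlorobenzyl amine

A few compounds are considered here, and "the series" means these few. Any claim that something is new, unique, unknown or untested is made for them only; others in the source may bear on it.

compound 1 `OC[C@H]1O[C@@H](n2cnc3c(NCc4ccccc4F)ncnc32)[C@H](O)[C@@H]1O`: > 166000 nM
compound 2 `Cc1ccc(CNc2ncnc3c2ncn3[C@@H]2O[C@H](CO)[C@@H](O)[C@H]2O)cc1`: "not determined" (no result reported)

In a functional assay on B16 cells (Mus musculus) for antiproliferative activity, with a stated time of 72 h (a higher number here means a weaker inhibitor, a lower number a stronger inhibitor), compound 1 gives only a limit, > 166000 nM, and this sits at the limit of > 166000 nM in this assay, at which 1 of the 2 values shown sits. For compound 2 the result in this assay is "not determined" (no result reported). Compound 3 `OC[C@H]1O[C@@H](n2cnc3c(NCc4ccc(Cl)c(Cl)c4)ncnc32)[C@H](O)[C@@H]1O` differs from compound 1 by 3,4-dichlorophenyl in place of 2-fluorophenyl on a saturated chain carbon bound to a nitrogen on an aromatic ring. Going by the values given here, no step between two measured compounds exists here, so the size of change this swap brings in this assay cannot be read from the data. Compound 3 is expected to give 150000 nM, estimated between 30000 nM and 500000 nM. The step expected an at least 1.1-fold lower number from compound 1 to compound 3 (0.04 log units; that floor lies within the scatter) is none beyond the scatter, with a limit again likely.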

Compound 3, half-maximal inhibitory concentration: > 166000 nM
Compound 3: a limit, no number; the forecaster's own chance of this, stated with the estimate: 70%; at least 1.1-fold (0.04 log units) between middle value and limit.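

Compound 1 and compound 3 each give only a limit in this assay, so no step can be read between them: the limit of > 166000 nM in this assay, at which 2 of the 3 values shown sit.

The compounds shown leave open whether 2-fluorobenzyl to 3,4-dichlorobenzyl changes the result in this assay at all.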